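Moving the methyl group on a hydrazide aryl ring

A few compounds are considered here, and "the series" means these few. Any claim that something is new, unique, unknown or untested is made for them only; others in the source may bear on it.

Three compounds have been measured in a functional assay on MDA-MB-231 cells (Homo sapiens) for antiproliferative activity, read by MTT assay, with a stated time of 24 h (a higher number here means a weaker inhibitor, a lower number a stronger inhibitor), so far:
Compound 1 `O=C(NNc1ccc(F)cc1)c1ccc(NS(=O)(=O)c2cnc(O)nc2O)cc1` gives > 20000 nM as a limit
Compound 2 `Cc1cccc(NNC(=O)c2cccc(NS(=O)(=O)c3cnc(O)nc3O)c2)c1` gives > 20000 nM as a limit
Compound 3 `Cc1ccccc1NNC(=O)c1ccccc1NS(=O)(=O)c1cnc(O)nc1O` gives > 20000 nM as a limit

In this assay compound 3 gives > 20000 nM and that value is a limit of the assay, not a number. The whole set sits at one place, the limit of > 20000 nM in this assay, at which 3 of the 3 values shown sit, and none of the three compounds has yet given a number.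

Compound 4 `Cc1cccc(NNC(=O)c2ccccc2NS(=O)(=O)c2cnc(O)nc2O)c1` has the same atoms as compound 3 but joined differently, with 3-methylphenyl in place of 2-methylphenyl on an amine nitrogen and nothing else altered. Compound 2 also carries 3-methylphenyl, and compound 2 gives > 20000 nM as a limit.

For the measured compounds named here, no step between measured compounds is available as a guide, so the expectation rests on these limits alone. No change beyond the usual scatter is expected in this assay and compound 4 will most likely report only a limit as well. The estimated step is a step that the limit leaves unreadable from compound 3 to compound 4 and it is expected to be small. The estimate for compound 4 is 22000 nM with an expected range from 8000 nM to 45000 nM in the same read-out.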

Compound 4, half-maximal inhibitory concentration: > 20000 nM
Compound 4: a limit, no number; the forecaster's own chance of this, stated with the estimate: 75%; the middle value does not contradict the limit.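

In this assay compound 4 gives > 20000 nM, which is a limit and not a number, so no step can be read between compound 3 and compound 4. The series stays at one place: the limit of > 20000 nM in this assay, at which 4 of the 4 values shown sit.

The compounds shown leave open how 3-methylphenyl and 2-methylphenyl compare on an amine nitrogen, since none of the four has yet given a number.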